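This account rests on a few compounds, and the source may have more. Where it says the series, first, only, none or still open, it means among the compounds named here.

Compound 1 `O[C@H](c1ccccn1)[C@]1(c2ccc(C(F)(F)F)cc2)C[C@@H](O)C1` and compound 2 `C[C@]1(O)C[C@@](c2ccc(C(F)(F)F)cc2)([C@H](O)c2ccccn2)C1` share one core, and compound 3 `O[C@H](c1ccccn1)[C@]1(c2ccnc(C(F)(F)F)c2)C[C@@H](O)C1` with the unmeasured compound 4 `C[C@]1(O)C[C@@](c2ccnc(C(F)(F)F)c2)([C@H](O)c2ccccn2)C1` another; how the two cores differ is not broken down here. In an ADME assay on liver for metabolic stability, with Liver microsome (Homo sapiens) as the target, read by LC-MS, using microsomes, with a stated time of 5 h (a lower number here means slower removal, a higher number faster removal of the compound), compound 1 gives 33.3 mL/min/kg, compound 2 gives 50 mL/min/kg, and compound 3 gives 83.3 mL/min/kg, the highest of the three numbers, beyond the scatter from compound 1 but within it from compound 2. The change from compound 1 to compound 2, (methyl in place of hydrogen on a saturated ring carbon), made a step of a 1.5-fold higher number from compound 1 to compound 2 (0.18 log units; within the scatter). The same kind of change is made from compound 3 to compound 4, (methyl in place of hydrogen on a saturated ring carbon), with the two place descriptions identical word for word. Since the step seen in compound 2 stayed within the scatter, a comparable step is expected here; compound 4 is estimated at a 1.3-fold higher number from compound 3 to compound 4 (0.12 log units; within the scatter), resting on the value of compound 3 83.3 mL/min/kg and on the earlier step of a 1.5-fold higher number from compound 1 to compound 2 (0.18 log units; within the scatter). Compound 4 is therefore expected to give about 110 mL/min/kg in this assay, between 60 mL/min/kg and 200 mL/min/kg.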

Compound 4, clearance: 66.7 mL/min/kg
The estimate for compound 4 lay 1.6-fold (0.22 log units) above the measured number, within the range that was stated.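

In this assay, methyl in place of hydrogen on the saturated ring carbon gave a 1.2-fold lower number from compound 3 to compound 4 (0.10 log units; within the scatter), and set beside the same change on the core of compound 1, the two steps do not separate: the same change on two cores in this assay, a 1.5-fold higher number (0.18 log units; within the scatter) from compound 1 to compound 2 and a 1.2-fold lower number (0.10 log units; within the scatter) from compound 3 to compound 4, 1.9-fold (0.27 log units) apart, within the scatter of two such steps. On both cores the change stayed within the scatter, so across these two pairs it carried over as a step too small to read, and the opposite directions of the two steps carry no weight. Going by these compounds alone, this does not show that the change would be equally small on any other core, as only two pairs stand here, and it gives no explanation for the size of either step.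

The compounds shown leave open whether an ethyl group or a longer chain in place of methyl at that ring carbon would give a step beyond the scatter. They also leave open how the methyl change would behave on a core carrying a nitrile in place of trifluoromethyl.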